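A few compounds are considered here, and "the series" means these few. Any claim that something is new, unique, unknown or untested is made for them only; others in the source may bear on it.

In a functional assay on U-373MG ATCC cells (Homo sapiens) for inhibition, read by MTT assay, with a stated time of 72 h (on this read-out lower numbers stand for stronger inhibition and higher numbers for weaker inhibition), compound 1 `CC1(C)CC(NC(=S)Nc2cccc(C#N)c2)c2cc(Br)ccc2O1` gives 6000 nM. Compound 2 `CC1(C)CC(NC(=S)Nc2ccc(Cl)cc2)c2cc(Br)ccc2O1` gives 7000 nM, and the change of aromatic group on the amide-type nitrogen makes a 1.2-fold higher number from compound 1 to compound 2 (0.07 log units; within the scatter). Compound 3 `CC1(C)CC(NC(=S)Nc2ccc(C#N)cc2)c2cc(Br)ccc2O1` gives 22000 nM, which amounts to a 3.7-fold higher number from compound 1 to compound 3 (0.56 log units; beyond the scatter) and to a 3.1-fold higher number from compound 2 to compound 3 (0.50 log units; beyond the scatter). Compound 1 therefore stands level with compound 2 at the low end of the three numbers, while compound 3 sits apart from both.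

Compound 4 `CC1(C)CC(NC(=S)Nc2cccc(C#N)c2)c2cc(Cl)ccc2O1` keeps the structure of compound 1 apart from one change, chloro in place of bromo on an aromatic carbon. Among the measured compounds shown here, none of the measured steps tests this swap directly, since all three alter the aromatic group on the amide-type nitrogen and leave the bromo in place. They offer only a rough sense of scale. The largest of them is a 3.7-fold higher number from compound 1 to compound 3 (0.56 log units; beyond the scatter), and the swap here exchanges one single-atom group for another, so no step beyond the scatter is expected in this assay, and no direction can be argued with confidence. The estimated result is a 1.2-fold higher number from compound 1 to compound 4 (0.07 log units; within the scatter). For compound 4 the estimated value is 7000 nM, with an expected range from 2500 nM to 20000 nM.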

Compound 4, half-maximal inhibitory concentration: 7000 nM
Beside the measured number, compound 4's estimate shows no gap at the digits printed; the measured number falls inside the stated range.
By their numbers in this assay, from the lowest: compounds 1, 2 and 4 (each within the scatter of the next); then compound 3.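

Until now every compound carried the bromo, so only the aromatic group on the amide-type nitrogen had been varied, and this position on the core had not been probed. In this assay, chloro in place of bromo gives a 1.2-fold higher number from compound 1 to compound 4 (0.07 log units; within the scatter), so with 3-cyanophenyl on the amide-type nitrogen, these two halogens cannot be told apart at this position, which is para to a fused ring on one side and meta to a fused ring on the other. No supporting measurement is available to say what lies behind this result.

Going by these compounds, what a group of a different kind at this position would do remains open, whether a methoxy, a trifluoromethyl, an amine or simply a hydrogen in place of the halogen. Also open, on these data alone, is whether chloro and bromo would match as closely with another aromatic group on the amide-type nitrogen, since this comparison rests on a single pair, with 4-chlorophenyl and 4-cyanophenyl seen only alongside the bromo.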